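The compounds below may be only part of what the source reports. "The series", "measured", "known", "first", "only" and "open" are said of these compounds alone.

Compound 1, `CCOC(=O)[C@H]1CC[C@@H](n2/c(=N/C(=O)c3ccccc3)[nH]c3ccc(CN4CCCCC4)cc32)CC1`, gives 222 mL.min-1.g-1 in an in vitro ADME assay on microsomes from liver (Homo sapiens) for metabolic stability; a higher number here means faster removal of the compound, a lower number slower removal.
Compound 2, `CC(C)NC(=O)[C@H]1CC[C@@H](n2/c(=N/C(=O)c3cccnc3)[nH]c3ccc(CN4CCC(C(C)(C)O)CC4)cc32)CC1`, gives 47 mL.min-1.g-1 in this assay.

Going by the values given here, of the two numbers measured so far, compound 2 stands at the lower one, and the gap up to compound 1 is wider than the usual scatter of repeated measurements, so compound 2 is the more slowly removed of the two. Compound 3, `CC(C)NC(=O)[C@H]1CC[C@@H](n2/c(=N/C(=O)c3ccncc3)[nH]c3ccc(CN4CCC(C(C)(C)O)CC4)cc32)CC1`, has not yet been measured in this assay. It is built from the same atoms as compound 2, joined differently: pyridin-4-yl in place of pyridin-3-yl on a carbonyl carbon. The group that leaves and the group that enters are both a six-membered aromatic ring with one nitrogen, and only the point at which that ring is attached to the carbonyl carbon moves. Among the compounds with values here, no pair of measured compounds shows what such a change does here, so there is no measured step to lean on. With so small a rearrangement, no step beyond the scatter is expected in either direction. Compound 3 is therefore expected to give about 47 mL.min-1.g-1, with a likely range from 22 mL.min-1.g-1 to 100 mL.min-1.g-1. The step of no change at the digits printed from compound 2 to compound 3 (within the scatter) is the expected outcome, small enough to fall within the scatter.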

Compound 3, intrinsic clearance in microsomes: 57 mL.min-1.g-1
The estimate for compound 3 lay 1.2-fold (0.08 log units) below the measured number; low and high end bracket the measured number.
By their numbers in this assay, from the lowest: compounds 2 and 3 (each within the scatter of the next); then compound 1.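

Placing pyridin-4-yl in place of pyridin-3-yl on the carbonyl carbon gives a 1.2-fold higher number from compound 2 to compound 3 (0.08 log units; within the scatter) in this assay, and this is the only pair shown that differs in just one place. It shows that, with the rest of the molecule held constant, moving the attachment point of this ring to the carbonyl carbon has no effect that can be told apart from the ordinary spread of repeated measurements, so these two pyridine attachments cannot be separated by this read-out. No measured evidence is available that would explain this result.

On these data alone, what a pyridin-2-yl group, or a pyrimidine ring with a second ring nitrogen, would give on this same carbonyl carbon remains open, as does the effect of a plain phenyl ring there with everything else in compound 2 kept the same. Compound 1 does carry a phenyl ring at this place, but it also differs from compound 2 elsewhere, including an ethyl ester and a plain piperidine, so its number cannot be assigned to any one of those differences.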